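Fluoro on the Aniline Ring of Compound 2

This account rests on a few compounds, and the source may have more. Where it says the series, first, only, none or still open, it means among the compounds named here.

Compound 1 `COc1ccc(NC(=O)CSc2ncc[nH]2)cc1OC`: 64%
Compound 2 `O=C(CSc1nc2cccnc2[nH]1)Nc1ccccc1`: 30%
Compound 3 `CC(=O)c1cccc(NC(=O)CSc2nc3cccnc3[nH]2)c1`: 50%

In an assay on isolated protein for inhibition of Ectonucleotide pyrophosphatase/phosphodiesterase family member 1 (Homo sapiens), tested at 10 uM (on this read-out lower numbers stand for less inhibition and higher numbers for more inhibition at the one concentration tested (going by the name of the read-out)), compound 2 stands lowest of the three, with compound 3 nearest and compound 1 furthest above it. Compound 4 `O=C(CSc1nc2cccnc2[nH]1)Nc1ccc(F)cc1` differs from compound 2 by fluoro in place of hydrogen on an aromatic carbon. Among the measured compounds shown here, only one measured step bears on this change: a number 20 percentage points higher from compound 2 to compound 3 (beyond the scatter), where acetyl in place of hydrogen on an aromatic carbon raised the number. Fluoro is a different and smaller group, so a step in the same direction but of smaller size is expected, one that may not clear the scatter. For compound 4 the expected step is a number 8 percentage points higher from compound 2 to compound 4 (within the scatter), giving an estimate of 38% with a range from 20% to 58%.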

Compound 4, a percentage reported as inhibition, at one concentration (the size of the read-out at that concentration, not a potency): 30%
Compound 4: the middle estimate sits 8 percentage points above what was measured, within the range that was stated.
By their numbers in this assay, from the lowest: compounds 2 and 4 (each within the scatter of the next); then compound 3; then compound 1.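

In this assay, fluoro in place of hydrogen, para to a large group, gives no change at the digits printed from compound 2 to compound 4 (within the scatter). So on this ring, a single fluorine atom at this place does not produce a rise like a number 20 percentage points higher from compound 2 to compound 3 (beyond the scatter), where the added group is acetyl. No measurement here explains why the number stays flat.

Still open, on these data alone, is whether an amine or a carboxylic acid at this same place would move the number. Fluoro elsewhere on the ring also remains an open question.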